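A few compounds are considered here, and "the series" means these few. Any claim that something is new, unique, unknown or untested is made for them only; others in the source may bear on it.

Measured compounds, a functional assay on HO8910 cells (Homo sapiens) for cytotoxicity, read by CCK-8 assay, with a stated time of 24 h; on this read-out higher numbers stand for weaker inhibition and lower numbers for stronger inhibition:
- compound 1, `C/C(=C\c1cc(-c2ccccc2)co1)C(N)=O`: 42400 nM
- compound 2, `C/C(=C\c1cc(-c2ccc(F)cc2)cs1)C(N)=O`: > 50000 nM
- compound 3, `C/C(=C\c1nc(-c2ccc(C)cc2)cs1)C(N)=O`: > 50000 nM

Working notes. Within the data shown here, compound 1 is the only member of the set with a numerical reading in this assay, at 42400 nM. Compound 2 gives only a limit of the assay, > 50000 nM, not a number. Compound 3 likewise reaches only a limit, > 50000 nM. So compound 2 stands where two of the three readings sit, at the limit (the limit of > 50000 nM in this assay, at which 2 of the 3 values shown sit), and nothing in this set separates it from compound 3; compound 1 is the one member that falls inside the measurable window.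

The next compound, compound 4, `C=Cc1ccc(-c2csc(/C=C(\C)C(N)=O)c2)cc1`, is not yet measured. It differs from compound 2 by vinyl in place of fluoro on an aromatic carbon of a six-membered aromatic ring of carbon only, para to a large group; the remaining framework is kept. Among the measured compounds shown here, no measured step in this set isolates such a change, so there is no direct precedent for its size or direction.

Given that compound 2 sits at the limit, the expectation for compound 4 is no shift beyond the scatter, the step from compound 2 to compound 4 estimated as an at least 1.1-fold lower number from compound 2 to compound 4 (0.04 log units; that floor lies within the scatter). Compound 4 is therefore estimated at 45000 nM, with a range from 15000 nM to 150000 nM, and a fair chance that this assay again reports only a limit.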

Compound 4, half-maximal inhibitory concentration: > 50000 nM
Compound 4 ended at the assay's limit; the forecaster's own chance of this, stated with the estimate: 60%; middle value at least 1.1-fold (0.04 log units) away from the limit.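

Compound 2 and compound 4 both end at a limit of the assay rather than at a number, so the step of vinyl in place of fluoro on an aromatic carbon cannot be read: the limit of > 50000 nM in this assay, at which 3 of the 4 values shown sit.

The compounds shown leave open where compound 2 and compound 4 truly lie beyond that limit, and whether this exchange changes the reading at all.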